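The source may hold more compounds than are shown below. What is called first, only, known or untested is meant among the compounds shown, and "the series" means these compounds.

In a functional assay on A-375 cells (Homo sapiens) for cytotoxicity, read by CCK-8 assay, with a stated time of 24 h (on this read-out higher numbers stand for weaker inhibition and lower numbers for stronger inhibition), compound 1 `COc1ccccc1Oc1c(N)nc(-c2cccc(C)c2)nc1Cl` gives 65300 nM, the higher of the two actual numbers available. Compound 3 `COc1ccccc1Oc1c(N)nc(-c2ccc(F)cc2)nc1Cl` gives 28200 nM. Compound 2 `COc1ccccc1Oc1c(N)nc(-c2ccc(C)cc2)nc1Cl` is reported only as a limit, > 80000 nM.

Compound 4 `COc1ccccc1Oc1c(N)nc(-c2cccc(C)c2)nc1OCCO` keeps the core of compound 1 and its 3-methylphenyl group but carries 2-hydroxyethoxy in place of chloro on an aromatic carbon. Among the measured compounds shown here, none of the measured steps touches this place, as all of them exchange the substituted phenyl group. They are a 2.3-fold lower number from compound 1 to compound 3 (0.36 log units; beyond the scatter), an at least 2.8-fold lower number from compound 2 to compound 3 (0.45 log units; beyond the scatter) and an at least 1.2-fold higher number from compound 1 to compound 2 (0.08 log units; that floor lies within the scatter). These steps show modest differences among three compounds, but they give no direction for the new group, so they bear on the coming step only as a rough guide to its size. No shift beyond the scatter is therefore expected, though with wide uncertainty in either direction. The expected change is a 1.3-fold lower number from compound 1 to compound 4 (0.12 log units; within the scatter). For compound 4 the estimated value is 50000 nM, with an expected range of 15000 nM to 100000 nM.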

Compound 4, half-maximal inhibitory concentration: 1380 nM
Compound 4: the middle estimate sits 36-fold (1.56 log units) above what was measured, outside the stated range (below it).
By their numbers in this assay, from the lowest: compound 4; then compound 3; then compound 1. At a limit, above all of these: compound 2.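

In this assay the exchange of chloro for 2-hydroxyethoxy gives a 47-fold lower number from compound 1 to compound 4 (1.68 log units; beyond the scatter) with the 3-methylphenyl group held constant. Among the compounds shown here, the earlier steps all changed the substituted phenyl group, so this is the first sign that the place next to the ring nitrogen can strongly move this read-out. The exchange takes away one chlorine and brings in a chain with one hydrogen-bond donor and two hydrogen-bond acceptors, but nothing measured here shows which of these features accounts for the step.

The compounds shown leave open whether the terminal hydroxy group is needed, which methoxy or 2-methoxyethoxy at this place would test, and whether a longer chain such as 3-hydroxypropoxy or an amine would behave alike. They also leave open whether 2-hydroxyethoxy has a similar effect alongside the 4-fluorophenyl group of compound 3.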